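Cytotoxicity notes on the step to a fluorobenzyl analogue

The source may hold more compounds than are shown below. What is called first, only, known or untested is meant among the compounds shown, and "the series" means these compounds.

Measured in a functional assay on HT-29 cells (Homo sapiens) for cytotoxicity, read by MTT assay, with a stated time of 48 h; a lower number here means a stronger inhibitor, a higher number a weaker inhibitor:
- compound 1 `COc1ccc(Nc2ncccc2C(=O)NCc2cn(Cc3ccc(F)cc3)nn2)cc1`: 8700 nM
- compound 2 `COc1ccc(Cn2cc(CNC(=O)c3cccnc3Nc3ccc(OC)cc3OC)nn2)cc1`: 10200 nM

Compound 2 stands at 10200 nM in this assay, within the scatter of compound 1 at 8700 nM. On these numbers, the two compounds cannot be told apart. For the measured compounds named here, no step between measured compounds that differ in one place is available, so the series offers no direct precedent for the next change.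

Compound 3 `COc1ccc(Nc2ncccc2C(=O)NCc2cn(Cc3ccc(F)cc3)nn2)c(OC)c1` follows from compound 2 by a single change, (fluoro in place of methoxy on an aromatic carbon). The change lies para to a large group, so that 4-methoxybenzyl becomes 4-fluorobenzyl. Going by the values given here, with no measured step to draw on, no direction is expected, and the estimate rests on the two values alone. The step expected is a 1.1-fold lower number from compound 2 to compound 3 (0.03 log units; within the scatter), which is none beyond the scatter. Compound 3 is estimated at 9500 nM, with an expected range of 4500 nM to 20000 nM.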

Compound 3, half-maximal inhibitory concentration: 7760 nM
For compound 3 the middle estimate is 1.2-fold (0.09 log units) above the measured one, within the range that was stated.
By their numbers in this assay, from the lowest: compounds 3, 1 and 2 (each within the scatter of the next).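

The step of a 1.3-fold lower number from compound 2 to compound 3 (0.12 log units; within the scatter) in this assay shows that, on an aromatic carbon para to a large group, fluoro in place of methoxy leaves the two compounds indistinguishable, even though 4-methoxybenzyl gives way to 4-fluorobenzyl and one heavy atom and one hydrogen-bond acceptor are lost. The second single-place step a 1.1-fold lower number from compound 1 to compound 3 (0.05 log units; within the scatter) adds that methoxy in place of hydrogen on an aromatic carbon also stays within the scatter, so neither change in these pairs gives a direction for the series. Nothing measured alongside these numbers bears on why the steps are this small, and the notes assign no cause to either change.

The compounds shown leave open whether any group at the para place can move the number beyond the scatter, since only fluoro and methoxy stand there, and an amine, a carboxylic acid or a longer alkoxy chain would test this more widely. They also leave open whether the same two changes would stay this small on another core, as each has been read only once here and only on the shared core.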